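This account rests on a few compounds, and the source may have more. Where it says the series, first, only, none or still open, it means among the compounds named here.

In an ADME assay on HEK293 cells (Homo sapiens) for cytotoxicity, read by MTT assay, with a stated time of 48 h (on this read-out higher numbers stand for weaker inhibition and lower numbers for stronger inhibition), compound 1 `CCCn1c(N)c(-c2nc3ccccc3[nH]2)c2nc(C#N)c(C#N)nc21` gives > 50000 nM, which is a limit of the assay. Compound 2 `CCCCn1c(N)c(-c2nc3ccccc3[nH]2)c2nc(C#N)c(C#N)nc21` gives > 50000 nM, also a limit. Compound 3 `N#Cc1nc2c(-c3nc4ccccc4[nH]3)c(N)n(CCCO)c2nc1C#N` gives > 50000 nM, again a limit. Compound 3 therefore stands at the limit of > 50000 nM in this assay, at which 3 of the 3 values shown sit.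

Compound 4 `CCN(CC)CCCCn1c(N)c(-c2nc3ccccc3[nH]2)c2nc(C#N)c(C#N)nc21` carries 4-(diethylamino)butyl where compound 3 carries 3-hydroxypropyl: (diethylamino)methyl in place of hydroxy on a saturated chain carbon, three bonds along the chain from an aromatic nitrogen.

Three measured steps at this chain carbon bear on the change: a step that the two limits leave unreadable from compound 1 to compound 2, a step that the two limits leave unreadable from compound 1 to compound 3 and a step that the two limits leave unreadable from compound 2 to compound 3. None of them gives a size to scale from, so the expectation is loose, and a reading that stays at the limit remains quite possible. The expected at least 1.6-fold lower number from compound 3 to compound 4 (0.22 log units; that floor lies within the scatter) is modest, toward stronger inhibition. Compound 4 is estimated at 30000 nM, with an expected range of 8000 nM to 60000 nM.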

Compound 4, half-maximal inhibitory concentration: 5370 nM
The estimate for compound 4 lay 5.6-fold (0.75 log units) above the measured number; the measured number lies below the stated range.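

In this assay, 4-(diethylamino)butyl is the only chain shown at this position that brings the number off the limit, and the change reads as an at least 9.3-fold lower number from compound 3 to compound 4 (0.96 log units; beyond the scatter), as an at least 9.3-fold lower number from compound 1 to compound 4 (0.96 log units; beyond the scatter) and, with the butyl chain held, as an at least 9.3-fold lower number from compound 2 to compound 4 (0.96 log units; beyond the scatter). The steps among compound 1, compound 2 and compound 3 cannot be read, as these compounds share one limit: the limit of > 50000 nM in this assay, at which 3 of the 4 values shown sit.

Going by these compounds, the full size of each step stays open. Also open, on these data alone, is whether a dimethylamino end group, a carboxylic acid or the shorter 3-(diethylamino)propyl chain would leave the limit as well.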